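Compound 3: a new group on a sulfonyl sulfur

The compounds below may be only part of what the source reports. "The series", "measured", "known", "first", "only" and "open" are said of these compounds alone.

Measured compounds:
compound 1 `N#Cc1ccc(S(=O)(=O)[C@H]2CN(S(=O)(=O)c3ccc(Cl)cc3C#N)C[C@@]2(O)CO)cc1` gives 2.6 L/kg
compound 2 `N#Cc1ccc(S(=O)(=O)[C@H]2CN(S(=O)(=O)c3ccc(C#N)cc3Cl)C[C@@]2(O)CO)cc1` gives 2.2 L/kg

Within the data shown here, in an ADME assay on the whole organism (Rattus norvegicus, strain Sprague-Dawley) for pharmacokinetics, read by LC-MS (a lower number here means that more of the compound stays in the plasma, a higher number that more of the compound sits outside the plasma), compound 2 at 2.2 L/kg lies within the scatter of compound 1, the only other compound measured, so the two cannot be told apart. Next comes compound 3 `N#Cc1ccc(S(=O)(=O)N2C[C@H](S(=O)(=O)c3ccc(Cl)cn3)[C@](O)(CO)C2)c(Cl)c1`, in which 5-chloropyridin-2-yl takes the place of 4-cyanophenyl on a sulfonyl sulfur (5-chloropyridin-2-yl in place of 4-cyanophenyl on a sulfonyl sulfur). Among the measured compounds shown here, the one measured step (a 1.2-fold lower number from compound 1 to compound 2 (0.07 log units; within the scatter)) changed a different group and stayed within the scatter. For the measured compounds named here, it bears on this change only indirectly, and no measured step removes the 4-cyanophenyl group. On this thin evidence, no shift beyond the scatter is expected in this assay and no direction is favoured. The expected change (a 1.1-fold higher number from compound 2 to compound 3 (0.04 log units; within the scatter)) is accordingly small. For compound 3 the estimate is 2.4 L/kg (expected range 1.2 L/kg to 4.8 L/kg).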

Compound 3, volume of distribution at steady state: 2 L/kg
The estimate for compound 3 lay 1.2-fold (0.08 log units) above the measured number; measured number inside the range.
By their numbers in this assay, from the lowest: compounds 3, 2 and 1 (each within the scatter of the next).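

Exchanging 4-cyanophenyl for 5-chloropyridin-2-yl on the sulfonyl sulfur whose other neighbour is a saturated ring carbon gives a 1.1-fold lower number from compound 2 to compound 3 (0.04 log units; within the scatter) in this assay. Among these compounds, this is the first measured step at this position, and it shows that losing the nitrile and bringing in a pyridine ring with a chlorine leaves compound 2 and compound 3 indistinguishable in this read-out. No measurement offers an explanation for this result.

The compounds shown leave open whether a carboxylic acid or an amine on the ring at this sulfonyl sulfur would give a step beyond the scatter. On these data alone, it also remains open whether 5-chloropyridin-2-yl would behave the same way alongside the 4-chloro-2-cyanophenyl group of compound 1.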